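Aryl swap on the aromatic nitrogen: outlook for compound 4

The source may report more compounds than this note shows. Statements on the series, on what has been measured and on what is new or still open speak of the compounds shown alone.

Three analogues share one core and differ only in the aryl group on an aromatic nitrogen. Compound 1 `N#CC1=C(N)Oc2c(N)cc3nc4ccccc4nc3c2C12C(=O)N(Cc1cnnn1-c1ccc(F)cc1)c1ccccc12` carries 4-fluorophenyl; in a functional assay on HepG2 cells (Homo sapiens) for antiproliferative activity, read by MTT assay, with a stated time of 48 h (a lower number here means a stronger inhibitor, a higher number a weaker inhibitor), compound 1 reaches only the assay limit, > 50000 nM. Compound 2 `N#CC1=C(N)Oc2c(N)cc3nc4ccccc4nc3c2C12C(=O)N(Cc1cnnn1-c1ccccc1Cl)c1ccccc12` carries 2-chlorophenyl, and in this assay compound 2 gives 33500 nM. Compound 3 `Cc1ccc(C)c(-n2nncc2CN2C(=O)C3(C(C#N)=C(N)Oc4c(N)cc5nc6ccccc6nc5c43)c3ccccc32)c1` carries 2,5-dimethylphenyl; in this assay compound 3 again sits at the limit, > 50000 nM. The steps of an at least 1.4-fold lower number from compound 1 to compound 2 (0.17 log units; that floor lies within the scatter) and an at least 1.4-fold higher number from compound 2 to compound 3 (0.17 log units; that floor lies within the scatter) are small, while a step that the two limits leave unreadable from compound 1 to compound 3; note (the limit of > 50000 nM in this assay, at which 2 of the 3 values shown sit). Compound 4 `CCc1cccc(CC)c1-n1nncc1CN1C(=O)C2(C(C#N)=C(N)Oc3c(N)cc4nc5ccccc5nc4c32)c2ccccc21` differs from compound 3 by 2,6-diethylphenyl in place of 2,5-dimethylphenyl on an aromatic nitrogen. Among the measured compounds shown here, no measured step covers this exact change; the expected step is a step that the limit leaves unreadable from compound 3 to compound 4, taking an at least 1.4-fold higher number from compound 2 to compound 3 (0.17 log units; that floor lies within the scatter) as the nearest guide. Compound 4 is estimated at 60000 nM, between 20000 nM and 180000 nM, most likely again a limit.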

Compound 4, half-maximal inhibitory concentration: 16500 nM
Estimate against measurement, compound 4: 3.6-fold (0.56 log units) above; measured number outside the range, below it.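

With 2,6-diethylphenyl on the aromatic nitrogen, the series shows an at least 3.0-fold lower number from compound 3 to compound 4 (0.48 log units; beyond the scatter) and a 2.0-fold lower number from compound 2 to compound 4 (0.31 log units; beyond the scatter) and an at least 3.0-fold lower number from compound 1 to compound 4 (0.48 log units; beyond the scatter) in this position. Among the compounds shown here, these are the first steps here printed as beyond the scatter, and they make compound 4 the strongest of the four in this assay on this aryl swap. Open, from the compounds shown here alone, is whether a longer chain such as propyl in place of each ethyl, or an amine on the phenyl ring, lowers the number further. The step between compound 1 and compound 3 cannot be read: the limit of > 50000 nM in this assay, at which 2 of the 4 values shown sit.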